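The compounds below may be only part of what the source reports. "The series", "measured", "known", "first", "only" and "open" are said of these compounds alone.

Four compounds sharing one core are compared here in a functional assay on PANC-1 cells (Homo sapiens) for cytotoxicity, read by MTT assay, with a stated time of 72 h; a higher number here means a weaker inhibitor, a lower number a stronger inhibitor. Compound 1 `O=C1C(Nc2ccc(-c3ccc(Cl)cc3)cc2)=CC(=O)c2ncncc21` gives 4400 nM, compound 2 `O=C1C(Nc2cccc(-c3ccccc3)c2)=CC(=O)c2ncncc21` gives 2300 nM, and compound 3 `O=C1C(Nc2ccc(C3CCCCC3)cc2)=CC(=O)c2ncncc21` gives 900 nM, the lowest number of the three. Compound 4 `O=C1C(Nc2ccc(N3CCCCC3)cc2)=CC(=O)c2ncncc21` has not yet been measured. It carries piperidin-1-yl in place of cyclohexyl on an aromatic carbon, para to a large group: piperidin-1-yl in place of cyclohexyl on an aromatic carbon. Among the measured compounds shown here, only one measured step bears on this place, the modest 4.9-fold lower number from compound 1 to compound 3 (0.69 log units; beyond the scatter), where cyclohexyl replaces 4-chlorophenyl. For the measured compounds named here, no measured pair shows what a ring nitrogen does in place of a ring carbon, so that step is only a rough guide. It swapped one ring for a quite different one, whereas this change keeps a six-membered non-aromatic ring, so a smaller step is expected here. The estimated step is a 1.4-fold higher number from compound 3 to compound 4 (0.16 log units; within the scatter), which stays within the scatter. Compound 4 is expected at 1300 nM, with an estimated range from 450 nM to 3500 nM.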

Compound 4, half-maximal inhibitory concentration: 1400 nM
The estimate for compound 4 lay 1.1-fold (0.03 log units) below the measured number; low and high end bracket the measured number.
By their numbers in this assay, from the lowest: compounds 3, 4, 2 and 1 (each within the scatter of the next, the first and the last beyond it).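

In this assay, putting a ring nitrogen where cyclohexyl had a ring carbon gives a 1.6-fold higher number from compound 3 to compound 4 (0.19 log units; within the scatter), so on this aromatic carbon, para to a large group, this exchange makes no difference that can be told from the scatter. Replacing 4-chlorophenyl with piperidin-1-yl gives a 3.1-fold lower number from compound 1 to compound 4 (0.50 log units; beyond the scatter), which means that a second six-membered non-aromatic ring, and not only cyclohexyl, stands apart from 4-chlorophenyl here. Nothing measured explains either step. Still open, on these data alone, is whether this tolerance extends to a ring with a second hetero atom, such as morpholin-4-yl, or to a ring of another size, such as pyrrolidin-1-yl. As far as these compounds go, an open chain at this place, such as butyl, is also untested by these compounds, so the need for a ring remains unknown.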